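A few compounds are considered here, and "the series" means these few. Any claim that something is new, unique, unknown or untested is made for them only; others in the source may bear on it.

Compound 1 `Clc1ccc(/C=N/Nc2nc(-c3ccccc3)c[se]2)cc1` and compound 2 `ClCc1c[se]c(N/N=C/c2csc(-c3ccccc3)n2)n1` differ by more than one change, so the difference between their two cores is not broken down here. In a functional assay on DU-145 cells (Homo sapiens) for cytotoxicity, read by XTT assay, with a stated time of 72 h (a higher number here means a weaker inhibitor, a lower number a stronger inhibitor), compound 1 gives 54200 nM, while compound 2 gives 16400 nM. Compound 3 `CC(=O)N(/N=C/c1ccc(Cl)cc1)c1nc(-c2ccccc2)c[se]1` comes from compound 1 through one change, (acetyl in place of hydrogen on a nitrogen on an aromatic ring). Compound 3 reaches only a limit of the assay, > 62000 nM, and this is the limit of > 62000 nM in this assay, at which 1 of the 3 values shown sits. Measured, that change gives an at least 1.1-fold higher number from compound 1 to compound 3 (0.05 log units; that floor lies within the scatter). Compound 4 `CC(=O)N(/N=C/c1csc(-c2ccccc2)n1)c1nc(CCl)c[se]1` comes from compound 2 through the same change, (acetyl in place of hydrogen on a nitrogen on an aromatic ring), at the same place. Resting on that earlier measured step, the expected step from compound 2 to compound 4 in this assay is a 1.8-fold higher number from compound 2 to compound 4 (0.26 log units; within the scatter). Compound 4 is therefore estimated to give 30000 nM, expected between 12000 nM and 62000 nM.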

Compound 4, half-maximal inhibitory concentration: 19600 nM
Estimate against measurement, compound 4: 1.5-fold (0.18 log units) above, within the range that was stated.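

In this assay, acetyl in place of hydrogen on a nitrogen on an aromatic ring gives a 1.2-fold higher number from compound 2 to compound 4 (0.08 log units; within the scatter), so on this core the change moves the number no further than the usual scatter. Set beside the other core, the comparison reads: the same change on two cores in this assay, an at least 1.1-fold higher number (0.05 log units; that floor lies within the scatter) from compound 1 to compound 3 and a 1.2-fold higher number (0.08 log units; within the scatter) from compound 2 to compound 4; the limit leaves it open whether they differ. As far as these compounds go, compound 3 gives > 62000 nM, which is a limit of the assay and not a number, so the true size of the step on the core of compound 1 stays unknown, and the change cannot be said to carry over unchanged.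

The compounds shown leave open what a methyl or a longer acyl chain such as butanoyl on that nitrogen would do. Among the compounds shown here, with only two cores, they also say nothing about the change on any other core.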